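Shortening the hydroxyalkyl amino chain: cytotoxicity expectation

A few compounds are considered here, and "the series" means these few. Any claim that something is new, unique, unknown or untested is made for them only; others in the source may bear on it.

In an ADME assay on Vero cells (Chlorocebus sabaeus) for cytotoxicity, with a stated time of 5 days (a higher number here means a weaker inhibitor, a lower number a stronger inhibitor), compound 1 `[N-]=[N+]=N[C@H]1C[C@H](n2cnc3c(NCCCCCO)nc(N)nc32)O[C@@H]1CO` gives > 100000 nM. That entry is a limit and not a number. Among the measured compounds shown here, compound 2 `[N-]=[N+]=N[C@H]1C[C@H](n2cnc3c(N)nc(F)nc32)O[C@@H]1CO` gives 34400 nM, the only actual number so far. It differs from compound 1 in more than one place, so no measured step can be read from this pair.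

Compound 3 `[N-]=[N+]=N[C@H]1C[C@H](n2cnc3c(NCCO)nc(N)nc32)O[C@@H]1CO` differs from compound 1 by hydroxy in place of 3-hydroxypropyl on a saturated chain carbon, two bonds along the chain from a nitrogen on an aromatic ring, which can also be read as (5-hydroxypentyl)amino to (2-hydroxyethyl)amino. For the measured compounds named here, no measured step gauges this shortening of the chain in this assay. The estimated a number no higher from compound 1 to compound 3 (the limit leaves the size open) is small, and no change beyond the scatter is expected, though any shift would be expected toward lower numbers. The lower end of the range rests on compound 2 at 34400 nM. For compound 3 the expected value is 100000 nM, with an estimated range of 40000 nM to 200000 nM.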

Compound 3, half-maximal inhibitory concentration: > 100000 nM
Compound 3: only a limit was reported; the forecaster's own chance of this, stated with the estimate: 65%; the middle value lies on the limit itself.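

No step can be read from compound 1 to compound 3 in this assay, because each compound is reported only as a limit and not as a number: the limit of > 100000 nM in this assay, at which 2 of the 3 values shown sit.

The compounds shown leave open how far replacing (5-hydroxypentyl)amino with (2-hydroxyethyl)amino shifts the value in this assay, if at all.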